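From a Branched Amine Chain to an Aminocyclohexyl Ring

The compounds below may be only part of what the source reports. "The series", "measured", "known", "first", "only" and "open" are said of these compounds alone.

Among the measured compounds shown here, compound 2 `C/C(=C/CN(C[C@H]1Cc2ccccc2CN1)[C@H]1CCCc2cccnc21)CN` gives the lowest number of the two measured so far in a functional assay on CCRF-CEM cells for antagonist activity at C-X-C chemokine receptor type 4 (Homo sapiens), read by calcium flux, with stated times of 25 min and 90 s (on this read-out higher numbers stand for weaker inhibition and lower numbers for stronger inhibition), namely 8.6 nM; compound 1 `C/C(CN)=C(/F)CN(C[C@H]1Cc2ccccc2CN1)[C@H]1CCCc2cccnc21` gives 44 nM, and the gap between them amounts to a 5.1-fold lower number from compound 1 to compound 2 (0.71 log units; beyond the scatter). Compound 3 `N[C@H]1CC[C@H](CN(C[C@H]2Cc3ccccc3CN2)[C@H]2CCCc3cccnc32)CC1` carries a group of 7 heavy atoms (6 carbon, 1 nitrogen; one six-membered non-aromatic ring of carbon only) in place of a group of 5 heavy atoms (4 carbon, 1 nitrogen; no ring), on a saturated chain carbon bound to an amine nitrogen. The only measured step, from compound 1 to compound 2, concerns the same position but a different exchange, so it bears on the new ring only indirectly, and no shown step sets a direction. Compound 3 is therefore expected to come in at about 15 nM, within 3 nM to 80 nM, which means a 1.7-fold higher number from compound 2 to compound 3 (0.24 log units; within the scatter).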

Compound 3, half-maximal inhibitory concentration: 280 nM
Compound 3: middle estimate off by 19-fold (1.27 log units), on the low side; the measured number lies above the stated range.
By their numbers in this assay, from the lowest: compound 2; then compound 1; then compound 3.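

In this assay the 4-aminocyclohexyl group produces the largest step seen at this position, with a 33-fold higher number from compound 2 to compound 3 (1.51 log units; beyond the scatter) and with a 6.4-fold higher number from compound 1 to compound 3 (0.80 log units; beyond the scatter) as well. Both open chains, in compound 1 and compound 2, thus give lower numbers than the ring of compound 3. Nothing available explains this rise. The compounds shown leave open whether the ring itself or the placing of its amine accounts for the step. They also do not show how a saturated 4-aminobutyl chain or a 4-(aminomethyl)cyclohexyl group would read here.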